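The source may hold more compounds than are shown below. What is called first, only, known or untested is meant among the compounds shown, and "the series" means these compounds.

Measured so far: compound 1 `NS(=O)(=O)CC(=O)NCCSc1nonc1/C(=N/O)Nc1cccc(C(F)F)c1` 1.5 h; compound 2 `CS(=O)(=O)CC(=O)NCCSc1nonc1/C(=N/O)Nc1ccc(F)c(C(F)F)c1` 0.765 h; compound 3 `O=C(NCCSc1nonc1/C(=N/O)Nc1ccc(F)c(C(F)F)c1)C1CS(=O)(=O)C1` 0.245 h, all in an ADME assay on microsomes from liver (Mus musculus) for metabolic stability; a lower number here means that the compound disappears faster, a higher number that the compound lasts longer.

Compound 3 stands lowest of the three, with compound 2 nearest and compound 1 furthest. Compound 4 `N#CCC(=O)NCCSc1nonc1/C(=N/O)Nc1ccc(F)c(C(F)F)c1` arises from compound 3 by a group of 3 heavy atoms (2 carbon, 1 nitrogen; no ring) in place of a group of 6 heavy atoms (3 carbon, 2 oxygen, 1 sulfur; one four-membered non-aromatic ring with 1 hetero atom), on a carbonyl carbon. Among the compounds with values here, the only measured step at this position, a 3.1-fold lower number from compound 2 to compound 3 (0.49 log units; beyond the scatter), is a modest change beyond the scatter, and it exchanged a chain for a ring rather than a ring for a nitrile chain; no step matches the present change directly. The account therefore expects compound 4 to move back up by about a 2.0-fold higher number from compound 3 to compound 4 (0.31 log units; beyond the scatter) in this assay, with wide uncertainty. Compound 4 is estimated at 0.5 h, between 0.2 h and 1.2 h.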

Compound 4, half-life: 0.278 h
Beside the measured number, compound 4's estimate is 1.8-fold (0.25 log units) above it, within the range that was stated.
By their numbers in this assay, from the lowest: compounds 3 and 4 (each within the scatter of the next); then compounds 2 and 1 (each within the scatter of the next).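

In this assay, a 1.1-fold higher number from compound 3 to compound 4 (0.05 log units; within the scatter) shows that cyanomethyl and the four-membered ring group on the carbonyl carbon cannot be told apart, although they differ in size and ring content. With cyano in place of methylsulfonyl, a 2.8-fold lower number from compound 2 to compound 4 (0.44 log units; beyond the scatter) shows that compound 2 stands apart from both compound 3 and compound 4 at this position. Nothing shown accounts for this split. On these data alone, whether an amine, a carboxylic acid or a longer chain on that carbonyl carbon would fall with compound 2 or with compound 3 and compound 4 remains open.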